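From Cyclopentyl to Cyclohexyl on a Shared Core

The compounds below may be only part of what the source reports. "The series", "measured", "known", "first", "only" and "open" are said of these compounds alone.

In a physicochemical assay for solubility, at pH 1.1 (a higher number here means a more soluble compound, a lower number a less soluble compound), compound 1 `CCN(Cc1ccc(OCCN2C(=O)CCC2=O)c(C)c1)C(CC(=O)O)c1ccc(Cl)cc1` gives 3000000 nM. Compound 2 `Cc1cc(CN(CC2CCCC2)C(CC(=O)O)c2ccc(Cl)cc2)ccc1OCCN1C(=O)CCC1=O` gives 3000000 nM, so the two compounds stand level at the digits reported. The next compound to be tested is compound 3 `Cc1cc(CN(CC2CCCCC2)C(CC(=O)O)c2ccc(Cl)cc2)ccc1OCCN1C(=O)CCC1=O`, which keeps the core of compound 2 and makes one structural change: cyclohexyl in place of cyclopentyl on a saturated chain carbon bound to an amine nitrogen. In short, cyclohexyl stands in place of cyclopentyl on a saturated chain carbon bound to an amine nitrogen.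

Within the data shown here, only one measured step bears on this change. no change at the digits printed from compound 1 to compound 2 (within the scatter) is the exchange of methyl for cyclopentyl at that same place, and it lies within the scatter. Among the measured compounds shown here, a single step is thin evidence, and no measured compound yet carries cyclohexyl. Still, the larger replacement in that step left this assay unmoved, so nothing in the data points to a shift in either direction here. The estimated step of no change at the digits printed from compound 2 to compound 3 (within the scatter) is expected to stay within the scatter, with no direction favoured. Compound 3 is expected at 3000000 nM, with an estimated range from 1500000 nM to 4000000 nM.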

Compound 3, solubility: 3000000 nM
Compound 3: the middle estimate sits on the measured number at the digits printed; the measured number falls inside the stated range.
By their numbers in this assay, from the lowest: compounds 1, 2 and 3 (each within the scatter of the next).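

In this assay, the step from the five-membered to the six-membered carbon ring reads as no change at the digits printed from compound 2 to compound 3 (within the scatter), so enlarging the ring at this place, on a saturated chain carbon bound to an amine nitrogen, leaves the reading unmoved. The step from methyl to cyclohexyl reads as no change at the digits printed from compound 1 to compound 3 (within the scatter), which means that compound 1, compound 2 and compound 3 now give the same printed number across methyl, cyclopentyl and cyclohexyl, and the earlier flat step no longer stands alone. Nothing measured here offers an explanation for this flat result.

All three groups at this place consist of carbon only, so the compounds shown leave open whether a group carrying a heteroatom, such as an amine or a carboxylic acid, or an aromatic ring such as phenyl, would hold this assay at the same number. They also leave open whether a change elsewhere on the shared core would shift the reading, as compound 1, compound 2 and compound 3 differ at this one place only.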